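Bicyclic nitrile series: amine variation at the five-membered ring

The source may hold more compounds than are shown below. What is called first, only, known or untested is meant among the compounds shown, and "the series" means these compounds.

Measured so far in an assay on isolated protein for binding affinity to Leucine-rich repeat serine/threonine-protein kinase 2 (Homo sapiens), read by TR-FRET and LanthaScreen, with a stated time of 2 h; a lower number here means a stronger inhibitor, a higher number a weaker inhibitor:
compound 1 `CN(C)c1c(C#N)c2c(N)ncnc2n1C` — 111 nM
compound 2 `C[C@@H]1CCCN1c1[nH]c2ncnc(N)c2c1C#N` — 4 nM

Compound 1 holds the highest of the two numbers; compound 2 comes in with a number far below it, beyond the scatter. The two compounds differ from one another in more than one place, so what the pair shows cannot be tied to a single change. Compound 3 `C[C@@H]1CCCN1c1c(C#N)c2c(N)ncnc2n1C` is not yet measured and differs from compound 1 in one place only: 2-methylpyrrolidin-1-yl in place of dimethylamino on an aromatic carbon. Compound 3 thus shares the 2-methylpyrrolidin-1-yl group with compound 2 while keeping the rest of compound 1. Given that compound 2, which also carries this group, gives 4 nM, a lowering of the number for compound 3 is expected, with the step from compound 1 estimated as a 4.4-fold lower number from compound 1 to compound 3 (0.65 log units; beyond the scatter), beyond the scatter. The estimate for compound 3 in this assay is 25 nM, within a range of 8 nM to 80 nM.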

Compound 3, inhibition constant: 0.4 nM
Estimate against measurement, compound 3: 63-fold (1.80 log units) above; measured number outside the range, below it.
By their numbers in this assay, from the lowest: compound 3; then compound 2; then compound 1.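

In this assay, going by these compounds alone, the position on the aromatic carbon next to the ring nitrogen responds strongly to the amine it carries: with methyl on the aromatic nitrogen held constant, 2-methylpyrrolidin-1-yl in place of dimethylamino gives a 280-fold lower number from compound 1 to compound 3 (2.44 log units; beyond the scatter) and is the largest step so far. With 2-methylpyrrolidin-1-yl held constant, methyl in place of hydrogen on the aromatic nitrogen gives a 10-fold lower number from compound 2 to compound 3 (1.00 log units; beyond the scatter) as a smaller but separate step. No measurement shown here accounts for either step.

Still open, on these data alone, is whether the amine step needs the ring, its methyl or the defined stereocentre; unsubstituted pyrrolidin-1-yl and the opposite 2-methylpyrrolidin-1-yl enantiomer would separate these. Also open, as far as these compounds go, is how an ethyl on the aromatic nitrogen compares with methyl.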